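The compounds below may be only part of what the source reports. "The series", "measured", "known", "first", "only" and "open" are said of these compounds alone.

Working notes on a small quinone-type series, all tested in a functional assay on BXPC-3 cells (Homo sapiens) for cytotoxicity, read by MTT assay, with a stated time of 72 h; on this read-out lower numbers stand for stronger inhibition and higher numbers for weaker inhibition.

Compound 3 `O=C1C=CC(=O)c2ncncc21` is the bare shared core, and in this assay compound 3 gives 19400 nM. Two anilino derivatives carry a substituted aromatic ring on the core. Compound 1 `Cc1ccc(-c2ccc(NC3=CC(=O)c4ncncc4C3=O)cc2F)cc1` gives 5000 nM, and compound 2 `COC(=O)c1ccc(NC2=CC(=O)c3ncncc3C2=O)cc1` gives 5800 nM. Among the three numbers compound 2 stands second highest: its nearest neighbour is compound 1, whose number sits within the scatter of the one for compound 2, so no order between them can be read; the furthest is compound 3, whose number lies beyond the scatter, so both anilino compounds clearly sit below the bare core in this assay.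

Compound 4 `COc1ccc(NC2=CC(=O)c3ncncc3C2=O)cc1` is not yet measured. It differs from compound 2 in one place: methoxy in place of methoxycarbonyl on an aromatic carbon. Both substituents sit on the same aromatic carbon of the six-membered aromatic ring of carbon only, and the anilino attachment to the core is untouched.

For the measured compounds named here, no measured pair in this set shows what such a swap does. Given that compound 1 gives 5000 nM while compound 2, with a quite different group on that ring, gives 5800 nM, the step is expected to be about a 1.1-fold lower number from compound 2 to compound 4 (0.05 log units; within the scatter), that is, none beyond the scatter. Compound 4 is therefore estimated at 5200 nM, with a range of 2000 nM to 13000 nM.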

Compound 4, half-maximal inhibitory concentration: 1700 nM
The estimate for compound 4 lay 3.1-fold (0.49 log units) above the measured number, outside the stated range (below it).
By their numbers in this assay, from the lowest: compound 4; then compounds 1 and 2 (each within the scatter of the next); then compound 3.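

In this assay, for the compounds shown here, methoxy in place of methoxycarbonyl on the aromatic carbon para to a large group gives a 3.4-fold lower number from compound 2 to compound 4 (0.53 log units; beyond the scatter), the first single-place change and one that moves the number beyond the scatter. The similar numbers of compound 1 and compound 2 therefore do not mean that this ring is insensitive to what it carries, since those two compounds differ in more than one place and could not show what one group does here. The step swaps a group of 4 heavy atoms, with a double bond and 2 hydrogen-bond acceptors, for one of 2 heavy atoms and 1 hydrogen-bond acceptor, but no measurement shown here bears on which of these differences matters.

A single pair cannot show whether the lower number belongs to methoxy itself or to the loss of methoxycarbonyl, so an amine, a carboxylic acid or an ethoxy group on the same carbon would be informative. Going by these compounds, it also remains open whether the same swap gives a similar step on the core of compound 1 or at another carbon of that ring.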